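Trading a Methoxyphenyl for a Chlorophenyl on the Urea

A few compounds are considered here, and "the series" means these few. Any claim that something is new, unique, unknown or untested is made for them only; others in the source may bear on it.

Measured so far:
compound 1 `O=C(Nc1cccc([N+](=O)[O-])c1)N[C@H]1CC[C@H](Oc2ccc(F)cc2)CC1` gives 6700 nM
compound 2 `COc1ccccc1NC(=O)N[C@H]1CC[C@H](Oc2ccc(F)cc2)CC1` gives > 20000 nM
compound 3 `O=C(Nc1cccc(C(F)(F)F)c1)N[C@H]1CC[C@H](Oc2cccc(F)c2)CC1` gives 2400 nM

Three ureas on the shared core have been run through a functional assay on CRL2813 cells (Homo sapiens) for cytotoxicity, read by sulforhodamine B assay, with a stated time of 5 days; on this read-out higher numbers stand for weaker inhibition and lower numbers for stronger inhibition. Compound 1 reaches 6700 nM and compound 3 reaches 2400 nM. As far as these compounds go, compound 2 is reported only as a limit of the assay, > 20000 nM, so its true value is unknown beyond that bound, as noted in the limit of > 20000 nM in this assay, at which 1 of the 3 values shown sits. Among the numbers shown, compound 2 therefore sits at the weak end.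

Compound 4 `O=C(Nc1ccc(Cl)cc1)N[C@H]1CC[C@H](Oc2ccc(F)cc2)CC1` is the next candidate, and it differs from compound 2 in a single place: 4-chlorophenyl in place of 2-methoxyphenyl on an amide-type nitrogen.

Going by the values given here, one measured step bears on this change. Going from compound 1 to compound 2, the swap of 3-nitrophenyl for 2-methoxyphenyl produced an at least 2.9-fold higher number from compound 1 to compound 2 (0.47 log units; beyond the scatter), a loss that runs at least modest. Compound 4 moves away from the 2-methoxyphenyl that accompanied that loss, back toward a halogenated aryl more in the spirit of compound 1 and compound 3. A recovery in this assay is therefore expected, though its size is uncertain given that compound 2 carries only a limit.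

Compound 4 is expected to give 5000 nM in this assay, within 1500 nM to 20000 nM, which would mean an expected step of an at least 4.0-fold lower number from compound 2 to compound 4 (0.60 log units; beyond the scatter).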

Compound 4, half-maximal inhibitory concentration: > 20000 nM
Compound 4: only a limit was reported; the forecaster's own chance of this, stated with the estimate: 25%; middle value at least 4.0-fold (0.60 log units) away from the limit.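

In this assay, the 4-chlorophenyl group on the amide-type nitrogen brings no readable gain over 2-methoxyphenyl, and the step between compound 2 and compound 4 cannot be read. What can be read is the comparison with 3-nitrophenyl at the same place: the change to 4-chlorophenyl gives an at least 2.9-fold higher number from compound 1 to compound 4 (0.47 log units; beyond the scatter). So two different aryl groups at this place, one carrying a methoxy group and one a chlorine, now both fall on the weak side of compound 1, and the order between them stays hidden because both values rest at the same limit of the assay: the limit of > 20000 nM in this assay, at which 2 of the 4 values shown sit.

The compounds shown leave open how far compound 2 and compound 4 lie from each other, and whether either has any measurable effect in these cells. They also leave open whether an unsubstituted phenyl group or a pyridyl group on the same nitrogen, with the rest of the core of compound 4 unchanged, would stay at that limit or come back into the measurable range.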